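Saturating the carboxyethenyl arm of compound 2

The compounds below may be only part of what the source reports. "The series", "measured", "known", "first", "only" and "open" are said of these compounds alone.

Compound 2 `COc1ccc(CCCCCCCCOc2ccc(CSCc3cccc(C(=O)O)c3)nc2/C=C/C(=O)O)cc1` gives 271 nM in a functional assay on the whole organism with Homo sapiens as the target (on this read-out lower numbers stand for stronger inhibition and higher numbers for weaker inhibition), the lowest of the three numbers measured. Compound 1 `COc1ccc(CCCCCCCCOc2ccc(CSc3cccc(C(=O)O)c3)nc2/C=C/C(=O)O)cc1` gives 1000 nM and compound 3 `COc1ccc(CCCCCCCCOc2ccc(C[S+]([O-])Cc3cccc(C(=O)O)c3)nc2/C=C/C(=O)O)cc1` gives 2600 nM. The measured steps are a 3.7-fold lower number from compound 1 to compound 2 (0.57 log units; beyond the scatter) and a 9.6-fold higher number from compound 2 to compound 3 (0.98 log units; beyond the scatter), and neither concerns the 2-carboxyethenyl group. Compound 4 `COc1ccc(CCCCCCCCOc2ccc(CSCc3cccc(C(=O)O)c3)nc2CCC(=O)O)cc1` differs from compound 2 in one place: 2-carboxyethyl in place of 2-carboxyethenyl on an aromatic carbon. Within the data shown here, no measured step bears on this change, so the expectation rests only on the size of the steps seen so far, which were all modest. For compound 4 a modestly higher number is estimated, 600 nM, with a range from 150 nM to 2500 nM. This expected step, a 2.2-fold higher number from compound 2 to compound 4 (0.35 log units; beyond the scatter), is uncertain in direction and could also lie within the scatter.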

Compound 4, half-maximal inhibitory concentration: 190 nM
For compound 4 the middle estimate is 3.2-fold (0.50 log units) above the measured one; the measured number falls inside the stated range.
By their numbers in this assay, from the lowest: compounds 4 and 2 (each within the scatter of the next); then compound 1; then compound 3.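

Swapping 2-carboxyethenyl for 2-carboxyethyl gives a 1.4-fold lower number from compound 2 to compound 4 (0.15 log units; within the scatter) in this assay, the first look at this arm. In this pair, then, the double bond of the arm can be lost without a change beyond the scatter, and the flexible saturated arm serves as well as the unsaturated one. Nothing available here explains this result.

Still open, from the compounds shown here alone, is whether a longer chain, such as 3-carboxypropyl, or a primary amide in place of this arm's carboxylic acid, would be tolerated. Also open, going by these compounds, is whether the same swap behaves alike in compound 1.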